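A few compounds are considered here, and "the series" means these few. Any claim that something is new, unique, unknown or untested is made for them only; others in the source may bear on it.

Compound 2 `NC(=S)N/N=C1/C(=O)N(CN2CCN(c3ccnc4cc(Cl)ccc34)CC2)c2cc(Cl)ccc21` carries a thiosemicarbazone on an indolinone core linked through a methylene to a piperazine bearing a chloroquinoline. For the measured compounds named here, in a functional assay on MCF7 cells (Homo sapiens) for cytotoxicity, read by sulforhodamine B assay, with a stated time of 48 h (on this read-out higher numbers stand for weaker inhibition of growth and lower numbers for stronger inhibition of growth), compound 2 gives 22500 nM, the lower of the two numbers measured so far. Compound 1 `NC(=S)N/N=C1/C(=O)N(CN2CCN(c3ccnc4cc(Cl)ccc34)CC2)c2cccc(Br)c21`, which carries a bromo instead at another position of the same core, gives in this assay 46600 nM, a gap that lies beyond the usual scatter of repeated runs. Compound 3 `NC(=S)N/N=C1/C(=O)N(CN2CCN(c3ccnc4cc(Cl)ccc34)CC2)c2ccccc21` differs from compound 2 by one small change: hydrogen in place of chloro on an aromatic carbon, so the core loses its only halogen. Going by the values given here, with no directly comparable pair measured, the expectation rests on the general finding that removing a halogen from this kind of core tends to weaken growth inhibition somewhat; a modest step toward a higher number, a 1.6-fold higher number from compound 2 to compound 3 (0.19 log units; within the scatter), is therefore expected. Compound 3 is accordingly estimated at 35000 nM in this assay, with a plausible range from 15000 nM to 80000 nM.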

Compound 3, concentration for 50% growth inhibition: 23000 nM
Compound 3: the middle estimate sits 1.5-fold (0.18 log units) above what was measured; the range from low to high includes it.
By their numbers in this assay, from the lowest: compounds 2 and 3 (each within the scatter of the next); then compound 1.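

In this assay, replacing the chloro of compound 2 with hydrogen gives a 1.0-fold higher number from compound 2 to compound 3 (0.01 log units; within the scatter) and so shows that, at this place on the ring, the chloro makes no readable difference to growth inhibition. Replacing the bromo of compound 1 with hydrogen gives a 2.0-fold lower number from compound 1 to compound 3 (0.31 log units; beyond the scatter) and is a real though modest step, so among these compounds the halogens do not share one effect: compound 1 carries a halogen and has the highest number, while compound 2 carries one and sits level with compound 3, which has none. No evidence here bears on why these two steps differ. Still open, as far as these compounds go, is whether an amine, a methoxy group or a carboxylic acid in place of the chloro would shift the number beyond the scatter. Also open, from the compounds shown here alone, is how a fluoro group would read at either halogen's place.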